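Fluoro on the benzyl of compound 1: cytotoxicity expectation

A few compounds are considered here, and "the series" means these few. Any claim that something is new, unique, unknown or untested is made for them only; others in the source may bear on it.

Measured compounds:
compound 1, `O=C1N(Cc2ccc(Cl)cc2Cl)c2cccn2S(=O)(=O)N1Cc1ccccc1`, 218000 nM
compound 2, `O=C1N(Cc2cccc(Cl)c2)c2cccn2S(=O)(=O)N1Cc1ccccc1`, 196000 nM
compound 3, `Cc1ccc(CN2C(=O)N(Cc3ccccc3)S(=O)(=O)n3cccc32)cc1`, 241000 nM

In an ADME assay on MT4 cells (Homo sapiens) for cytotoxicity, read by MTT assay, with a stated time of 5 days (a higher number here means that more compound is tolerated, a lower number that less compound is tolerated), compound 1 stands second highest of the three numbers, with compound 3 nearest and compound 2 furthest, and all three numbers lie within the scatter of one another. Compound 4, `O=C1N(Cc2ccc(Cl)cc2Cl)c2cccn2S(=O)(=O)N1Cc1cccc(F)c1`, differs from compound 1 by fluoro in place of hydrogen on an aromatic carbon, the phenyl becoming 3-fluorophenyl. Within the data shown here, no measured step touches this ring; the steps that are known change the other ring on the shared core, and each was small: a 1.1-fold lower number from compound 1 to compound 2 (0.05 log units; within the scatter), a 1.1-fold higher number from compound 1 to compound 3 (0.04 log units; within the scatter), a 1.2-fold higher number from compound 2 to compound 3 (0.09 log units; within the scatter). With nothing in these data pointing beyond the scatter, compound 4 is expected to give 210000 nM in this assay, between 110000 nM and 400000 nM. That estimate means a 1.0-fold lower number from compound 1 to compound 4 (0.02 log units; within the scatter), no step beyond the scatter.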

Compound 4, half-maximal cytotoxic concentration: > 249000 nM
Compound 4: no number, only a limit; the forecaster's own chance of this, stated with the estimate: 10%; middle value at least 1.1-fold (0.07 log units) away from the limit.
By their numbers in this assay, from the lowest: compounds 2, 1 and 3 (each within the scatter of the next). At a limit, above all of these: compound 4.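

Compound 4 gives no number in this assay, only a limit: the limit of > 249000 nM in this assay, at which 1 of the 4 values shown sits.

The earlier steps shown here changed the other ring, whereas this one touches the phenyl, and fluoro in place of hydrogen gives an at least 1.1-fold higher number from compound 1 to compound 4 (0.05 log units; that floor lies within the scatter). This phenyl therefore takes fluoro on an aromatic carbon, meta to a large group, with no lower number, though how high the number lies cannot be read.

As far as these compounds go, whether an amine or a carboxylic acid at this place would leave the number where it stands remains open, as does fluoro on any other carbon of this phenyl.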